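The source may hold more compounds than are shown below. What is called first, only, known or untested is meant among the compounds shown, and "the series" means these compounds.

Measured so far:
- compound 1, `CC(=O)Oc1ccc(C(=O)Nc2cc3ccc(OCC4CCCN(C)C4)c(C)c3oc2=O)cc1CC=C(C)C`: 740 nM
- compound 2, `CC(C)=CCc1cc(C(=O)Nc2cc3ccc(OCCCN4CCCCC4)c(C)c3oc2=O)ccc1O`: > 50000 nM

In a functional assay on SK-BR-3 cells (Homo sapiens) for antiproliferative activity (on this read-out lower numbers stand for stronger inhibition and higher numbers for weaker inhibition), compound 1 gives 740 nM. Compound 2 reaches only the limit of > 50000 nM in this assay, at which 1 of the 2 values shown sits, in this assay; this value is a limit, not a number, so compound 2 stands at the weak end of the two values shown and the gap between compound 1 and compound 2 cannot be sized beyond saying it is larger than the scatter. Among the compounds with values here, no single-change step between the two measured compounds exists, since they differ in more than one place.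

Compound 3, `CCCNCCCOc1ccc2cc(NC(=O)c3ccc(O)c(CC=C(C)C)c3)c(=O)oc2c1C`, is not yet measured. It differs from compound 2 in one place: propylamino in place of piperidin-1-yl on a saturated chain carbon, three bonds along the chain from an oxygen on an aromatic ring. The change keeps the free phenol and the three-carbon chain from the aromatic oxygen of compound 2 and replaces the ring amine with an open-chain secondary amine.

Within the data shown here, with compound 2 at a limit, no measured step offers a direction for this change, and a step of an at least 1.2-fold lower number from compound 2 to compound 3 (0.09 log units; that floor lies within the scatter) is expected, that is, no shift beyond the scatter that can be asserted from the data. Compound 3 is therefore estimated at 40000 nM, in the range 8000 nM to 200000 nM, with a substantial chance that this assay again returns only a limit.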

Compound 3, half-maximal inhibitory concentration: 990 nM
The estimate for compound 3 lay 40-fold (1.61 log units) above the measured number; the measured number lies below the stated range.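

In this assay, within the data shown here, replacing 3-(piperidin-1-yl)propyl with 3-(propylamino)propyl gives an at least 50-fold lower number from compound 2 to compound 3 (1.70 log units; beyond the scatter), the first single change seen to move the read-out beyond the scatter. With the rest of compound 2 unchanged, this shows that activity in this assay responds strongly to the group on a saturated chain carbon, three bonds along the chain from an oxygen on an aromatic ring, and that, with compound 3 at 990 nM, the free phenol does not rule out activity. The step has only a floor, and its full size stays unknown, as compound 2 stands at a limit and not a number: the limit of > 50000 nM in this assay, at which 1 of the 3 values shown sits.

The change removes a six-membered ring and adds a hydrogen-bond donor at once, and the compounds shown do not separate the two; a dimethylamino group at this place, open-chain without that donor, would do so. As far as these compounds go, how far the open-chain amine tolerates other sizes also remains open, for example with ethylamino or butylamino in place of propylamino.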